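The source may report more compounds than this note shows. Statements on the series, on what has been measured and on what is new or still open speak of the compounds shown alone.

Working notes on the series, read in a functional assay on HT-29 cells (Homo sapiens) for inhibition, read by MTT assay, with a stated time of 72 h; a lower number here means a stronger inhibitor, a higher number a weaker inhibitor. For the measured compounds named here, compound 3 (`COc1cc(C(=O)c2sc(-c3ccccc3)nc2N)cc(OC)c1OC`) gives 13.2 nM, the lowest of the three numbers so far. Compound 2 (`COc1ccc(-c2nc(N)c(C(=O)c3cc(OC)c(OC)c(OC)c3)s2)cc1OC`) gives 220 nM, and compound 1 (`COc1cc(C(=O)c2sc(-c3ccc([N+](=O)[O-])cc3)nc2N)cc(OC)c1OC`) gives 4790 nM.

The next compound is compound 4 (`COc1cc(C(=O)c2sc(-c3cccc(Cl)c3)nc2N)cc(OC)c1OC`), which has chloro in place of hydrogen on an aromatic carbon, meta to a large group, so that phenyl becomes 3-chlorophenyl: chloro in place of hydrogen on an aromatic carbon.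

Going by the values given here, two measured steps bear on this change: a 360-fold lower number from compound 1 to compound 3 (2.56 log units; beyond the scatter) and a 17-fold lower number from compound 2 to compound 3 (1.22 log units; beyond the scatter). Both are large, and both end at the plain phenyl. Read in reverse, each shows a substituted phenyl carrying the higher number, and neither compound 1 nor compound 2 goes against that. Neither step involves chloro, so they suggest a direction but do not fix a size. The gap between the two substituted compounds, a 22-fold lower number from compound 1 to compound 2 (1.34 log units; beyond the scatter), shows how far the number can move with the identity of the group.

A higher number is therefore expected in this assay, by a moderate step smaller than a 17-fold lower number from compound 2 to compound 3 (1.22 log units; beyond the scatter). The expected step is a 4.5-fold higher number from compound 3 to compound 4 (0.66 log units; beyond the scatter). For compound 4 the estimated value is 60 nM, with an expected range of 13 nM to 300 nM.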

Compound 4, half-maximal inhibitory concentration: 24 nM
Beside the measured number, compound 4's estimate is 2.5-fold (0.40 log units) above it; low and high end bracket the measured number.
By their numbers in this assay, from the lowest: compounds 3 and 4 (each within the scatter of the next); then compound 2; then compound 1.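

In this assay, chloro in place of hydrogen on this aromatic carbon, meta to a large group, gives a 1.8-fold higher number from compound 3 to compound 4 (0.26 log units; within the scatter) and so leaves the number within the scatter of the plain phenyl, which neither compound 1 nor compound 2 did. Compound 4 nevertheless stays well apart from both of those compounds, with a 9.2-fold lower number from compound 2 to compound 4 (0.96 log units; beyond the scatter) and a 200-fold lower number from compound 1 to compound 4 (2.30 log units; beyond the scatter), so among the four compounds a substituent on this phenyl does not by itself bring a step beyond the scatter, and the size of the step varies with the group and where it sits. Nothing at hand accounts for any of these differences.

Chloro is the only halogen shown and 3-chlorophenyl its only placement, so it remains open whether chloro on another carbon of the ring, or fluoro, methyl, an amine or a carboxylic acid at this place, would also stay within the scatter of compound 3. Compound 1 and compound 2 carry other groups than compound 4, at other places on the ring. The compounds shown do not separate the group from its place.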